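Compound 1 to compound 4: swapping a piperidine side chain

The source may hold more compounds than are shown below. What is called first, only, known or untested is meant among the compounds shown, and "the series" means these compounds.

Compound 1 `c1ccc2c(c1)CN[C@@H](CN(CC1CCNCC1)[C@H]1CCCc3cccnc31)C2`: 86%
Compound 2 `c1ccc2c(c1)CN[C@@H](CN(CCCN1CCNCC1)[C@H]1CCCc3cccnc31)C2`: 100%
Compound 3 `CN1CCN(CCCN(C[C@H]2Cc3ccccc3CN2C)[C@H]2CCCc3cccnc32)CC1`: 60%

These values come from an ADME assay on microsomes from liver (Homo sapiens) for metabolic stability, read by LC-MS, with a stated time of 10 min, tested at 0.5 uM; a higher number here means that more of the compound is left, a lower number that less of the compound is left. Compound 1 stands second of the three, under compound 2 and over compound 3. Compound 4 `CCN1CCN(CCCN(C[C@H]2Cc3ccccc3CN2)[C@H]2CCCc3cccnc32)CC1` is not yet measured, and its change from compound 1 is 2-(4-ethylpiperazin-1-yl)ethyl in place of piperidin-4-yl on a saturated chain carbon bound to an amine nitrogen. The nearest measured step is a number 14 percentage points higher from compound 1 to compound 2 (beyond the scatter), which brings in the unsubstituted 2-(piperazin-1-yl)ethyl. That step points upward, but compound 3, also substituted on its piperazine, reads 60%. The two pull in opposite directions, so only a slight drop is expected, namely a number 8 percentage points lower from compound 1 to compound 4 (within the scatter). For compound 4 the expected value is 78%. The estimated range for compound 4 runs from 58% to 95%.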

Compound 4, percent of the compound remaining: 59%
Beside the measured number, compound 4's estimate is 19 percentage points above it, and the stated range covers the measured number.
By their numbers in this assay, from the lowest: compounds 4 and 3 (each within the scatter of the next); then compound 1; then compound 2.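

In this assay the ethyl in place of hydrogen on an amine nitrogen in a ring carries a large penalty, with a number 41 percentage points lower from compound 2 to compound 4 (beyond the scatter) standing as the sharpest drop at this position. The side chain's direction relative to the piperidin-4-yl of compound 1 therefore reverses once the ethyl is present, with a number 27 percentage points lower from compound 1 to compound 4 (beyond the scatter) in place of the earlier rise. Nothing measured here gives a reason for this. On these data alone, whether an acetyl or a 2-hydroxyethyl on that same ring nitrogen would leave more of the compound remaining stays open.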